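Replacing benzyl with (4-cyanophenyl)sulfonyl on an aromatic nitrogen

This account rests on a few compounds, and the source may have more. Where it says the series, first, only, none or still open, it means among the compounds named here.

Compound 1 `COc1ccc(-c2cc(=O)c3c(OC)cc(OC)cc3n2Cc2ccccc2)cc1` was examined in an ADME assay on BJ cells (Homo sapiens) for antiproliferative activity, with a stated time of 72 h; a higher number here means that more compound is needed for the effect, a lower number that less compound is needed. In this assay compound 1 gave only a limit, > 34400 nM, not a number. Compound 2 `COc1ccc(-c2c(I)c(=O)c3c(OC)cc(OC)cc3n2S(=O)(=O)c2ccc(OC)cc2)cc1` likewise gave only a limit, > 34400 nM. Among the measured compounds shown here, the evidence so far is therefore (the limit of > 34400 nM in this assay, at which 2 of the 2 values shown sit), and no measured step between these compounds exists. Compound 3 `COc1ccc(-c2cc(=O)c3c(OC)cc(OC)cc3n2S(=O)(=O)c2ccc(C#N)cc2)cc1` differs from compound 1 by (4-cyanophenyl)sulfonyl in place of benzyl on an aromatic nitrogen. The step that the limit leaves unreadable from compound 1 to compound 3 is expected to be none beyond the usual scatter. Compound 3 is therefore estimated at about 40000 nM, between 15000 nM and 120000 nM, most likely again reported as a limit.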

Compound 3, half-maximal effective concentration: > 17200 nM
Compound 3 was reported as a limit; the forecaster's own chance of this, stated with the estimate: 80%; the middle value does not contradict the limit.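

Compound 1 and compound 3 both gave only limits in this assay, so no step can be read between them. The compounds shown leave open whether (4-cyanophenyl)sulfonyl in place of benzyl alters antiproliferative activity at all.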